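Adding a Further Methoxy Group to Compound 2

The compounds below may be only part of what the source reports. "The series", "measured", "known", "first", "only" and "open" are said of these compounds alone.

Within the data shown here, compound 2 `COc1ccc(/C=N/c2c(C)n(C)n(-c3ccccc3)c2=O)cc1OC` holds the higher of the two numbers recorded in a functional assay on HT-29 cells (Homo sapiens) for cytotoxicity, read by MTT assay, with a stated time of 72 h (on this read-out lower numbers stand for stronger inhibition and higher numbers for weaker inhibition), where compound 2 gives 603000000 nM, though the gap to its only neighbour lies within the scatter. That neighbour, compound 1 `COc1ccc(/C=N/c2c(C)n(C)n(-c3ccccc3)c2=O)cc1`, gives 589000000 nM in this assay. Compound 3 `COc1cc(/C=N/c2c(C)n(C)n(-c3ccccc3)c2=O)cc(OC)c1OC` differs from compound 2 by methoxy in place of hydrogen on an aromatic carbon. Among the measured compounds shown here, the single measured step that bears on this change is a 1.0-fold higher number from compound 1 to compound 2 (0.01 log units; within the scatter), which likewise brought in a methoxy in place of hydrogen on an aromatic carbon and left the number essentially where it was. On that basis no step beyond the scatter is expected for compound 3 in this assay, and the estimated step is a 1.0-fold lower number from compound 2 to compound 3 (0.00 log units; within the scatter). Compound 3 is therefore expected to give about 600000000 nM in this assay, with a range from 300000000 nM to 1200000000 nM.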

Compound 3, half-maximal inhibitory concentration: 275000000 nM
Beside the measured number, compound 3's estimate is 2.2-fold (0.34 log units) above it; measured number outside the range, below it.
By their numbers in this assay, from the lowest: compound 3; then compounds 1 and 2 (each within the scatter of the next).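

In this assay, methoxy in place of hydrogen at this position, ortho to a methoxy group and meta to a large group, gives a 2.2-fold lower number from compound 2 to compound 3 (0.34 log units; beyond the scatter), which shows that this exchange can move the number beyond the scatter, if only modestly. The same kind of exchange gave a 1.0-fold higher number from compound 1 to compound 2 (0.01 log units; within the scatter), so across these three compounds the outcome of adding a methoxy group is not constant, and a single earlier step does not carry over to this position.

The compounds shown leave open whether a hydroxyl group, an amine or a longer chain such as ethoxy at this position would give a step of similar size and direction. Nothing available here explains why this step differs from the earlier one.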